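Swapping a hydroxy for a morpholinylsulfonyl on the aminothiazole core

The compounds below may be only part of what the source reports. "The series", "measured", "known", "first", "only" and "open" are said of these compounds alone.

Of the compounds shown here, three sharing one core have been measured in an assay on isolated protein for inhibition of Polyunsaturated fatty acid 5-lipoxygenase (Homo sapiens), with stated times of 15 min and 10 min; a higher number here means a weaker inhibitor, a lower number a stronger inhibitor. Compound 1 `Oc1cccc(Nc2nc(-c3ccc(Cl)cc3)cs2)c1` gives 5600 nM. Compound 2 `CCOc1ccc(-c2csc(Nc3ccc(O)cc3)n2)cc1` gives 600 nM, the lowest number of the three. Compound 3 `Oc1ccc(-c2csc(Nc3ccc(Cl)cc3)n2)cc1` gives 3100 nM, the second highest of the three numbers. Its nearest neighbour is compound 1, whose number lies within the scatter of that of compound 3, so no order between these two can be read. Compound 2, by contrast, sits clearly beyond the scatter with a lower number than compound 3.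

Compound 4 `O=S(=O)(c1ccc(-c2csc(Nc3ccc(Cl)cc3)n2)cc1)N1CCOCC1` differs from compound 3 in one place: (morpholin-4-yl)sulfonyl in place of hydroxy on an aromatic carbon. For the measured compounds named here, no measured pair shows a change of this kind, so nothing among the measured compounds tells how large such a step should be.

Given that, the step from compound 3 to compound 4 in this assay is expected to be a small rise in number, a 1.9-fold higher number from compound 3 to compound 4 (0.29 log units; within the scatter), at the edge of the scatter. Compound 4 is accordingly estimated at 6000 nM, with a plausible range from 1500 nM to 25000 nM.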

Compound 4, half-maximal inhibitory concentration: > 30000 nM
Compound 4: only a limit was reported; the forecaster's own chance of this, stated with the estimate: 15%; middle value at least 5.0-fold (0.69 log units) from the limit.
By their numbers in this assay, from the lowest: compound 2; then compounds 3 and 1 (each within the scatter of the next). At a limit, above all of these: compound 4.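

In this assay compound 4 yields only a limit of the assay, > 30000 nM, and not a number. Replacing the hydroxy on this aromatic carbon, para to a large group, with (morpholin-4-yl)sulfonyl gives an at least 9.6-fold higher number from compound 3 to compound 4 (0.98 log units; beyond the scatter), so the step lies beyond the scatter and its full size stays unknown, as the reading is bounded on one side only: the limit of > 30000 nM in this assay, at which 1 of the 4 values shown sits. This is the first change in a single place among the compounds shown, and it establishes what the three earlier compounds could not: in this series, the group at this position can decide whether inhibition remains measurable, since compound 3 with its hydroxy still gives a number in the same assay.

The compounds shown leave open whether the loss belongs to the sulfonyl link or to the morpholine ring, as the two enter together in one step, and how far beyond the limit compound 4 truly lies. They also leave open how a plain sulfonamide, an amine or a carboxylic acid on this same aromatic carbon would behave, so the step cannot yet be read as a trend.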